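Oxadiazole sulfonamides: benzyl to arylamino-methyl swap

This account rests on a few compounds, and the source may have more. Where it says the series, first, only, none or still open, it means among the compounds named here.

Measured so far in an assay on CHO cells for displacement of a labelled ligand from prostaglandin E2 receptor EP1 subtype (Homo sapiens); on this read-out higher numbers stand for weaker inhibition and lower numbers for stronger inhibition:
compound 1 `CCc1ccccc1N(Cc1nnc(Cc2ccccc2)o1)S(=O)(=O)c1ccc(C)cc1` gives 1000 nM
compound 2 `COc1ccc(Cc2nnc(CN(c3cccc(C(F)(F)F)c3C)S(=O)(=O)c3ccc(C)cc3)o2)cc1` gives 63.1 nM
compound 3 `Cc1ccc(S(=O)(=O)N(Cc2nnc(Cc3cccc(F)c3)o2)c2cccc(Cl)c2C)cc1` gives 316 nM

Compound 3 holds the second highest of the three numbers: compound 1 sits higher by a margin beyond the scatter, compound 2 lower by a larger margin, also beyond the scatter. Compound 4 `COc1ccc(NCc2nnc(CN(c3cccc(Cl)c3C)S(=O)(=O)c3ccc(C)cc3)o2)cc1` is not yet measured. The change from compound 3 is (4-methoxyphenyl)amino in place of 3-fluorophenyl on a saturated chain carbon bound to an aromatic carbon. Among the compounds with values here, no pair of measured compounds differs in this one place, so the step has no direct precedent; compound 2, the lowest number, carries a methoxyphenyl group but also a different substituent on the sulfonamide aniline. A modest downward step is expected, a 1.6-fold lower number from compound 3 to compound 4 (0.20 log units; within the scatter), with wide uncertainty. Compound 4 is estimated at 200 nM, range 40 nM to 1000 nM.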

Compound 4, half-maximal inhibitory concentration: 20 nM
Estimate against measurement, compound 4: 10-fold (1.00 log units) above, and the stated range ends above it.
By their numbers in this assay, from the lowest: compound 4; then compound 2; then compound 3; then compound 1.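

In this assay, within the data shown here, the swap gives a 16-fold lower number from compound 3 to compound 4 (1.20 log units; beyond the scatter) and is the first single-place step. This position therefore has a large bearing on the read-out, and (4-methoxyphenyl)amino is accepted here in place of 3-fluorophenyl. The step changes the ring substituents and the amino nitrogen together, so one comparison cannot separate them. No evidence bearing on the cause is available.

Open: whether the gain follows the amino nitrogen or the methoxy group. Unsubstituted phenylamino, or an ether oxygen in place of the amino nitrogen, would separate the two.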